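The source may report more compounds than this note shows. Statements on the series, on what has been measured and on what is new or still open speak of the compounds shown alone.

Compound 3 `CC(O)CNc1nc(-c2ccccc2)nc2c1nnn2Cc1ccccc1Cl` is assessed in an assay on Cerebral cortex for displacement of a labelled ligand from adenosine receptor A1 (Bos taurus) (a higher number here means a weaker inhibitor, a lower number a stronger inhibitor), where compound 3 gives 32 nM. Among the three measured members, compound 2 `OCCNc1nc(-c2ccccc2)nc2c1nnn2Cc1ccccc1F` gives 54 nM, a number within the scatter of that for compound 3, while compound 1 `CCCNc1nc(-c2ccccc2)nc2c1nnn2Cc1ccccc1F` gives 3.2 nM, a lower number beyond the scatter. For the measured compounds named here, the only single-point step recorded is a 17-fold higher number from compound 1 to compound 2 (1.23 log units; beyond the scatter), which concerns the chain rather than the ring. Compound 4 `CC(O)CNc1nc(-c2ccccc2)nc2c1nnn2Cc1ccccc1F` differs from compound 3 by fluoro in place of chloro on an aromatic carbon. Going by the values given here, no measured step isolates this halogen exchange; compounds 2 and 3 differ in two places at once, so only their two values can be compared. The step of a 1.1-fold lower number from compound 3 to compound 4 (0.03 log units; within the scatter) is therefore expected to stay within the scatter. The estimate for compound 4 in this assay is 30 nM, ranging from 10 nM to 90 nM.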

Compound 4, inhibition constant: 4.8 nM
Compound 4: middle estimate off by 6.3-fold (0.80 log units), on the high side; the measured number lies below the stated range.
By their numbers in this assay, from the lowest: compounds 1 and 4 (each within the scatter of the next); then compounds 3 and 2 (each within the scatter of the next).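

In this assay, for the compounds shown here, the halogen on this aromatic carbon matters: the step of a 6.7-fold lower number from compound 3 to compound 4 (0.82 log units; beyond the scatter) is the first direct reading of fluoro in place of chloro, and it lies beyond the scatter. With fluoro held constant, methyl in place of hydrogen on the chain carbon bearing the oxygen gives an 11-fold lower number from compound 2 to compound 4 (1.05 log units; beyond the scatter). Hydroxy in place of hydrogen on the chain gives a 1.5-fold higher number from compound 1 to compound 4 (0.18 log units; within the scatter), which stays within the scatter.

Nothing available explains these steps. On these data alone, it remains open how a bromo or methoxy group would read at this place, and whether the exchange of chloro for fluoro keeps its size on a chain without the hydroxy.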